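The source may hold more compounds than are shown below. What is called first, only, known or untested is meant among the compounds shown, and "the series" means these compounds.

Measured so far in a functional assay on NB-4 cells (Homo sapiens) for cytotoxicity, read by CCK-8 assay, with a stated time of 24 h; a lower number here means a stronger inhibitor, a higher number a weaker inhibitor:
Compound 1 `C=CC(=O)N1C(=O)CC(c2ccc([N+](=O)[O-])cc2)Sc2ccccc21` gives 37700 nM.
Compound 2 `C=CC(=O)N1C(=O)CC(c2ccc(C)cc2)Sc2ccccc21` gives 37300 nM.
Compound 3 `C=CC(=O)N1C(=O)CC(c2ccc(C(F)(F)F)cc2)Sc2ccccc21` gives 38600 nM.

Compound 2 has the lowest of the three numbers, but a 1.0-fold lower number from compound 1 to compound 2 (0.00 log units; within the scatter) and a 1.0-fold higher number from compound 2 to compound 3 (0.01 log units; within the scatter) are both within the scatter, as is a 1.0-fold higher number from compound 1 to compound 3 (0.01 log units; within the scatter), so nothing separates compound 2 from compounds 1 and 3 in this assay.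

Compound 4 `C=CC(=O)N1C(=O)CC(c2cccs2)Sc2ccccc21` is not yet measured. It differs from compound 2 in that (thiophen-2-yl in place of 4-methylphenyl on a saturated ring carbon). Going by the values given here, the three measured steps only swap one group for another on an aromatic carbon of the six-membered ring; none exchanges the ring itself, so no step bears directly on this change. Those steps were all within the scatter, and no number beyond the scatter is expected for a 1.0-fold higher number from compound 2 to compound 4 (0.01 log units; within the scatter). Compound 4 is estimated at 38000 nM, between 15000 nM and 95000 nM.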

Compound 4, half-maximal inhibitory concentration: 765000 nM
For compound 4 the middle estimate is 20-fold (1.30 log units) below the measured one; the measured number lies above the stated range.
By their numbers in this assay, from the lowest: compounds 2, 1 and 3 (each within the scatter of the next); then compound 4.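

Thiophen-2-yl in place of 4-methylphenyl on the saturated ring carbon gives a 21-fold higher number from compound 2 to compound 4 (1.31 log units; beyond the scatter) in this assay and so shows that this position responds to an exchange of the ring itself, whereas the group swaps among compounds 1, 2 and 3 stayed within the scatter. This single step cannot separate ring size from the ring sulfur. No measurement shown here explains the step.

Open, from the compounds shown here alone, is whether plain phenyl or furan-2-yl at this carbon tracks compound 2 or compound 4. Also open, going by these compounds, is whether an amine or carboxylic acid on the six-membered ring would shift the number.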